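Trimming the Methoxy Groups from Compound 3 to Compound 4

The compounds below may be only part of what the source reports. "The series", "measured", "known", "first", "only" and "open" are said of these compounds alone.

Of the compounds shown here, three have been measured so far. Compound 1 `C=CCc1ccc(O)c(-c2cc(CC=C)cc(CN(C)C(C)C)c2O)c1` carries the smallest aminomethyl substituent, and in an assay on isolated protein for inhibition of Maltase-glucoamylase (Homo sapiens), with stated times of 15 min and 10 min, tested at 64 uM (on this read-out higher numbers stand for more inhibition at the one concentration tested (going by the name of the read-out) and lower numbers for less inhibition), compound 1 gives 3.4%. Compound 2 `C=CCc1cc(-c2ccc(O)c(CC=C)c2)c(O)c(C(c2cc(OC)c(OC)c(OC)c2)N2CCCC2)c1` bears a 3,4,5-trimethoxyphenyl group and a pyrrolidin-1-yl ring on the same saturated carbon; in this assay compound 2 gives 43%. Compound 3 `C=CCc1cc(-c2ccc(O)c(CC=C)c2)c(O)c(C(c2cc(OC)c(OC)c(OC)c2)N2CCCCC2)c1` keeps the same aryl group but with piperidin-1-yl instead, and in this assay compound 3 gives 56.4%, the highest of the three numbers; compound 2 lies nearest to it and compound 1 furthest. Within the data shown here, the only single-point step, a number 13.4 percentage points higher from compound 2 to compound 3 (beyond the scatter), is modest yet beyond the scatter.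

Compound 4 `C=CCc1cc(-c2ccc(O)c(CC=C)c2)c(O)c(C(c2ccccc2)N2CCCCC2)c1` is the next analogue: phenyl in place of 3,4,5-trimethoxyphenyl on a saturated chain carbon bound to an amine nitrogen in a ring and an aromatic carbon. Among the measured compounds shown here, no measured step bears on this part of the molecule; the step from compound 2 to compound 3 concerns the ring on the nitrogen, not the aryl group, so it offers no direction for the present change. Removing three methoxy groups from the aryl ring is an untested move here, so a moderate downward step is expected, a number 16.4 percentage points lower from compound 3 to compound 4 (beyond the scatter), with wide uncertainty. Compound 4 is therefore estimated at 40%, within a range from 15% to 65%.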

Compound 4, a percentage reported as inhibition, at one concentration (the size of the read-out at that concentration, not a potency): 13.6%
Compound 4: middle estimate off by 26.4 percentage points, on the high side; measured number outside the range, below it.
By their numbers in this assay, from the lowest: compound 1; then compound 4; then compound 2; then compound 3.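

In this assay, putting phenyl in place of 3,4,5-trimethoxyphenyl on a saturated chain carbon bound to an amine nitrogen in a ring and an aromatic carbon gives a number 42.8 percentage points lower from compound 3 to compound 4 (beyond the scatter), which shows that the aryl group at this position has a large bearing on the read-out even with the piperidin-1-yl ring held constant. This step is larger than the only earlier one, a number 13.4 percentage points higher from compound 2 to compound 3 (beyond the scatter), so among the two steps shown, the change of aryl group moves the number more than the change of ring on the nitrogen. Nothing available explains why the loss of the three methoxy groups goes with this drop.

The compounds shown leave open whether all three methoxy groups are required or whether one or two would keep the number up, and whether a hydroxyl, a fluorine or a dimethylamino group on the phenyl ring could stand in their place. They also leave open whether the same exchange of aryl group would give a step of similar size with pyrrolidin-1-yl on the nitrogen.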